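The compounds below may be only part of what the source reports. "The series", "measured", "known", "first", "only" and "open" are said of these compounds alone.

The compounds measured so far:

compound 1, `COc1ccc(-n2c(=O)n(Cc3cc4cc(Cl)ccc4n3CCCC#N)c3cnccc32)cc1OC`: in an ADME assay on HeLa cells (Homo sapiens) for cytotoxicity, read by ATP content, with a stated time of 3 days (on this read-out lower numbers stand for higher toxicity in this test and higher numbers for lower toxicity in this test), compound 1 gives > 50000 nM, which is a limit of the assay and not a number.
compound 2, `O=c1n(Cc2cc3ccc(Cl)cc3n2CCCCO)c2cnccc2n1C1CC1`: in this assay compound 2 gives > 50000 nM, again a limit rather than a number.

Compound 1 therefore stands nowhere on a scale of numbers: its reading is a limit, and the one other reading shown is a limit too, so that (the limit of > 50000 nM in this assay, at which 2 of the 2 values shown sit). Compound 3, `Cn1ccc(-n2c(=O)n(Cc3cc4cc(Cl)ccc4n3CCCC#N)c3cnccc32)n1`, differs from compound 1 in one place: 1-methyl-1H-pyrazol-3-yl in place of 3,4-dimethoxyphenyl on an aromatic nitrogen. Among the compounds with values here, no step between two measured compounds is available for this change, so nothing measured says what it does in this assay. The expected step of a number no higher from compound 1 to compound 3 (the limit leaves the size open) is none beyond the usual scatter. Compound 3 is estimated to give 50000 nM in this assay, with a range from 20000 nM to 100000 nM, and most likely again only a limit.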

Compound 3, half-maximal cytotoxic concentration: > 50000 nM
Compound 3 ended at the assay's limit; the forecaster's own chance of this, stated with the estimate: 80%; the middle value lies on the limit itself.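

In this assay, within the data shown here, compound 3 gives > 50000 nM, a limit of the assay and not a number; with compound 1 also at a limit, no step between compound 1 and compound 3 can be read. What 1-methyl-1H-pyrazol-3-yl in place of 3,4-dimethoxyphenyl does to the reading stays open: the limit of > 50000 nM in this assay, at which 3 of the 3 values shown sit.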